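Methyl for fluoro on the benzyl ring of an indazole series

The source may hold more compounds than are shown below. What is called first, only, known or untested is meant among the compounds shown, and "the series" means these compounds.

Measured compounds:
compound 1, `Oc1ccc(CNc2cc(Br)cc3[nH]ncc23)c(F)c1`: 69%
compound 2, `Oc1ccc(CNc2cc(Br)cc3[nH]ncc23)cc1F`: 52%
compound 3, `Cc1cc(CNc2cc(Br)cc3[nH]ncc23)ccc1O`: 28%

In an assay for inhibition of Indoleamine 2,3-dioxygenase 1 (Homo sapiens), with a stated time of 1 h, tested at 10 uM (on this read-out higher numbers stand for more inhibition at the one concentration tested (going by the name of the read-out) and lower numbers for less inhibition), compound 1 gives the highest of the three numbers; compound 2 gives 52% and compound 3 gives 28%. Compound 1 and compound 2 have the same atoms joined differently; the difference between the two cores is not broken down here. From compound 2 to compound 3 the change is methyl in place of fluoro on an aromatic carbon, and the step is a number 24 percentage points lower from compound 2 to compound 3 (beyond the scatter). Compound 4, `Cc1cc(O)ccc1CNc1cc(Br)cc2[nH]ncc12`, carries the same kind of change made on compound 1, (methyl in place of fluoro on an aromatic carbon), though here the new methyl sits ortho to a large group and meta to a hydroxy group, not ortho to the hydroxy group. For the measured compounds named here, because the one measured step of a number 24 percentage points lower from compound 2 to compound 3 (beyond the scatter) is a modest drop, a drop of about that size is expected, a number 22 percentage points lower from compound 1 to compound 4 (beyond the scatter). For compound 4 in this assay a value of 47% is estimated, between 25% and 70%.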

Compound 4, a percentage reported as inhibition, at one concentration (the size of the read-out at that concentration, not a potency): 60%
Compound 4: middle estimate off by 13 percentage points, on the low side, within the range that was stated.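

Putting methyl in place of fluoro on the core of compound 1 gives a number 9 percentage points lower from compound 1 to compound 4 (within the scatter) in this assay, so compound 1 and compound 4 cannot be told apart on this read-out. The size of the step therefore does not carry over unchanged from one core to the other: the same change on two cores in this assay, a number 24 percentage points lower (beyond the scatter) from compound 2 to compound 3 and a number 9 percentage points lower (within the scatter) from compound 1 to compound 4, 15 percentage points apart, beyond the scatter of two such steps These two pairs do not show what lies behind the gap, and they give no rule for any other core.

The compounds shown leave open how other groups on that same aromatic carbon, such as chloro, methoxy or a nitrile, would read on each core. They also leave open whether an amine or a carboxylic acid could stand in place of the hydroxy group.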